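Acetyl on the amine nitrogen of compound 2

The source may report more compounds than this note shows. Statements on the series, on what has been measured and on what is new or still open speak of the compounds shown alone.

Measured compounds in a functional assay on LNCaP cells (Homo sapiens) for cytotoxicity, read by WST assay, with a stated time of 48 h; a lower number here means a stronger inhibitor, a higher number a weaker inhibitor:
compound 1 `CC(=O)NCCCO/N=C\c1ccc(F)cc1`, 20 nM
compound 2 `NCCCO/N=C\c1cccc(C(=O)O)c1`, 20 nM

Compound 2 stands level with compound 1 in this assay, the two values agreeing within the scatter; compound 1 differs from it in more than one place, so no single step can be read between them. Compound 3 `CC(=O)NCCCO/N=C\c1cccc(C(=O)O)c1` is not yet measured. It differs from compound 2 by acetyl in place of hydrogen on an amine nitrogen, so that compound 3 carries the acetamido group of compound 1 on the aryl of compound 2. Going by the values given here, no measured pair isolates this change. Since compound 1, which holds the same acetamido chain, gives 20 nM and compound 2 gives 20 nM, no step beyond the scatter is expected in this assay for compound 3. The expected step is no change at the digits printed from compound 2 to compound 3 (within the scatter). For compound 3 the estimate in this assay is 20 nM, expected between 8 nM and 50 nM.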

Compound 3, half-maximal inhibitory concentration: 20 nM
Compound 3: the middle estimate sits on the measured number at the digits printed, and the stated range covers the measured number.
By their numbers in this assay, from the lowest: compounds 1, 2 and 3 (each within the scatter of the next).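

In this assay the series now has its first pair differing in one place: acetyl in place of hydrogen on an amine nitrogen gives no change at the digits printed from compound 2 to compound 3 (within the scatter). At this nitrogen, whose other neighbour is a saturated chain carbon, amino and acetamido therefore read alike with the aryl of compound 2 held constant, even though the change adds 3 heavy atoms. No measurement on hand offers an explanation for this result.

One acetyl on one aryl cannot show whether the same holds for a benzoyl or a methyl on this nitrogen, or for a longer chain between the nitrogen and the oxygen. The steps involving compound 1 cannot be read, as it differs from the other two compounds in more than one place, so the free amine on the aryl of compound 1 would be needed to test this change there.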